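Replacing Chloro with a Methylcyclohexenyl Ring

The source may report more compounds than this note shows. Statements on the series, on what has been measured and on what is new or still open speak of the compounds shown alone.

Compound 1 `CC(C(=O)NCc1ccc(C(F)(F)F)nc1Cl)c1ccc(NS(C)(=O)=O)c(F)c1` gives the lowest of the two numbers in an assay on CHO cells for antagonist activity at transient receptor potential cation channel subfamily V member 1 (Homo sapiens), read by FLIPR and calcium flux (on this read-out higher numbers stand for weaker inhibition and lower numbers for stronger inhibition), namely 0.2 nM. Among the compounds with values here, compound 2 `CCCc1nc(C(F)(F)F)ccc1CNC(=O)C(C)c1ccc(NS(C)(=O)=O)c(F)c1`, which carries propyl in place of chloro on an aromatic carbon, gives 22.7 nM in this assay, and the step of a 110-fold higher number from compound 1 to compound 2 (2.05 log units; beyond the scatter) is the one measured change that bears on the new compound. Compound 3 `CC1C=C(c2nc(C(F)(F)F)ccc2CNC(=O)C(C)c2ccc(NS(C)(=O)=O)c(F)c2)CCC1` differs from compound 1 by 3-methylcyclohex-1-en-1-yl in place of chloro on an aromatic carbon. Since a carbon group again replaces chloro at the same place, a comparably large weakening is expected. Compound 3 is therefore estimated at 40 nM, most likely between 5 nM and 400 nM. The expected step is a 200-fold higher number from compound 1 to compound 3 (2.30 log units; beyond the scatter).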

Compound 3, inhibition constant: 0.2 nM
Compound 3: the middle estimate sits 200-fold (2.30 log units) above what was measured; the measured number lies below the stated range.
By their numbers in this assay, from the lowest: compounds 1 and 3 (each within the scatter of the next); then compound 2.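

The result shows that a carbon group at this position, next to the ring nitrogen, need not weaken inhibition: 3-methylcyclohex-1-en-1-yl in place of chloro gives no change at the digits printed from compound 1 to compound 3 (within the scatter). Putting the same ring in place of propyl gives a 110-fold lower number from compound 2 to compound 3 (2.05 log units; beyond the scatter), so the loss seen with propyl does not extend to every carbon group here. Nothing available explains why the two carbon groups differ. Still open, going by these compounds, is whether the ring's methyl or its double bond matters, and how a phenyl ring, a longer chain or an amine would fare at this position.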